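This account rests on a few compounds, and the source may have more. Where it says the series, first, only, none or still open, it means among the compounds named here.

Measured compounds:

compound 1, `Cc1ccc(S(=O)(=O)NC(=O)Nc2ccccc2C(=O)/C=C/c2cccc(F)c2)cc1` — in an ADME assay on the whole organism for cytotoxicity, with Artemia salina as the target, with a stated time of 24 h (a lower number here means that less compound is needed, a higher number that more compound is needed for the effect), compound 1 gives 4.13 ug/mL
compound 2, `Cc1ccc(S(=O)(=O)NC(=O)Nc2ccccc2C(=O)/C=C/c2ccc(Cl)cc2Cl)cc1` — in this assay compound 2 gives 8.34 ug/mL

Compound 2 holds the highest of the two numbers in this assay; its nearest neighbour is compound 1, and the change between them is a 2.0-fold higher number from compound 1 to compound 2 (0.31 log units; beyond the scatter). Compound 3, `Cc1ccc(S(=O)(=O)NC(=O)Nc2ccccc2C(=O)/C=C/c2cccc(Br)c2)cc1`, has not yet been measured. It differs from compound 2 by 3-bromophenyl in place of 2,4-dichlorophenyl on a double-bonded chain carbon bound to a double-bonded chain carbon, so the ring at the end of the chain now carries its bromine at the third position, as the fluorine in compound 1 does. Within the data shown here, the only measured step that bears on this change is the one from compound 1 to compound 2, a modest rise. Since compound 3 returns to a pattern closer to that of compound 1, a step back toward the number of compound 1 is expected: a 1.7-fold lower number from compound 2 to compound 3 (0.22 log units; within the scatter). Compound 3 is therefore estimated at 5 ug/mL, within a range from 2.5 ug/mL to 10 ug/mL, because compound 1 with its 3-fluorophenyl gave 4.13 ug/mL.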

Compound 3, concentration for half-maximal effect: 4.02 ug/mL
Estimate against measurement, compound 3: 1.2-fold (0.09 log units) above; low and high end bracket the measured number.
By their numbers in this assay, from the lowest: compounds 3 and 1 (each within the scatter of the next); then compound 2.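

In this assay, replacing 2,4-dichlorophenyl with 3-bromophenyl on a double-bonded chain carbon bound to a double-bonded chain carbon gives a 2.1-fold lower number from compound 2 to compound 3 (0.32 log units; beyond the scatter), a step about as large as the earlier rise but opposite in direction. Bromo in place of fluoro on an aromatic carbon gives a 1.0-fold lower number from compound 1 to compound 3 (0.01 log units; within the scatter), so this exchange of halogens on the 3-substituted ring is not resolved in this assay, and among the three compounds only the 2,4-dichlorophenyl compound stands apart. Nothing shown offers a measured reason for either step.

The compounds shown do not separate the number of chlorines from where they sit, since a ring with a single chlorine is not among them. As far as these compounds go, how a methoxy group or an amine on this ring would read also remains open.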